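The compounds below may be only part of what the source reports. "The series", "measured", "known", "first", "only" and "open" are said of these compounds alone.

The three measured compounds share one core and differ only in the group carried on an amine nitrogen in a ring, and all were tested in a functional assay on MKN-74 cells (Homo sapiens) for antiproliferative activity, with a stated time of 24 h; on this read-out lower numbers stand for stronger inhibition and higher numbers for weaker inhibition. Compound 1 `NC(=O)c1c(NC(=O)c2ccccc2Cl)sc2c1CCNC2` carries hydrogen on that nitrogen, and in this assay compound 1 gives 28700 nM. Compound 2 `NC(=O)c1c(NC(=O)c2ccccc2Cl)sc2c1CCN(Cc1ccccc1)C2` carries a benzyl there, and in this assay compound 2 gives 14500 nM. Compound 3 `NC(=O)c1c(NC(=O)c2ccccc2Cl)sc2c1CCN(Cc1cc(Cl)cc(Cl)c1)C2` carries a 3,5-dichlorobenzyl, and in this assay compound 3 gives 23700 nM, the second highest of the three numbers. Each pair of these compounds lies within the scatter of each other: the steps are a 2.0-fold lower number from compound 1 to compound 2 (0.30 log units; within the scatter), a 1.2-fold lower number from compound 1 to compound 3 (0.08 log units; within the scatter) and a 1.6-fold higher number from compound 2 to compound 3 (0.21 log units; within the scatter).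

Compound 4 `CSc1ccccc1NC(=S)N1CCc2c(sc(NC(=O)c3ccccc3Cl)c2C(N)=O)C1` differs from compound 3 in one place: a group of 11 heavy atoms (8 carbon, 1 nitrogen, 2 sulfur; one six-membered aromatic ring of carbon only) in place of a group of 9 heavy atoms (7 carbon, 2 chlorine; one six-membered aromatic ring of carbon only), on an amine nitrogen in a ring. The three steps above all bear on this, since each one swaps the group on the same nitrogen, and none of them moved the number beyond the scatter. Within the data shown here, no measured step swaps in a group of this kind, so nothing more specific can be drawn. Compound 4 is therefore expected to give a number near that of compound 3, which means an expected step of a 1.2-fold lower number from compound 3 to compound 4 (0.07 log units; within the scatter). The estimate for compound 4 is 20000 nM, expected to fall between 6000 nM and 60000 nM.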

Compound 4, half-maximal inhibitory concentration: 13800 nM
Estimate against measurement, compound 4: 1.4-fold (0.16 log units) above; low and high end bracket the measured number.
By their numbers in this assay, from the lowest: compounds 4, 2, 3 and 1 (each within the scatter of the next, the first and the last beyond it).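

The group on this amine nitrogen can be exchanged for one of quite different make-up, with sulfur, a nitrogen, a double bond outside aromatic rings and a hydrogen-bond donor, without a clear change in this assay: the comparison gives a 1.7-fold lower number from compound 3 to compound 4 (0.23 log units; within the scatter) against the 3,5-dichlorobenzyl group and a 1.1-fold lower number from compound 2 to compound 4 (0.02 log units; within the scatter) against the benzyl group. Among these compounds, replacing the hydrogen on that nitrogen gives a 2.1-fold lower number from compound 1 to compound 4 (0.32 log units; beyond the scatter) and is the first step to lie beyond the scatter, though only modestly, while compounds 2 and 3 remain within the scatter of compound 1 and so go against any general rule that a group here lowers the number. No other data on these compounds bear on this result.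

Which part of the new group matters stays open, as its sulfur atoms, nitrogen and aromatic ring all enter in a single step. Also open, on these data alone, is how the number would respond to an acetyl group, a longer alkyl chain or a carboxylic acid on this nitrogen.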